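Moving the thiophene attachment point in a pyridine-linked series

This account rests on a few compounds, and the source may have more. Where it says the series, first, only, none or still open, it means among the compounds named here.

Compound 2, with the structure `c1ccc(-c2cc(-c3ccsc3)cc(-c3cccnc3)n2)nc1`, gives in a functional assay on HCT-15 cells (Homo sapiens) for antiproliferative activity (on this read-out lower numbers stand for stronger inhibition of growth and higher numbers for weaker inhibition of growth), only a limit, namely > 100 ug/mL, so its true number is not known; this is the limit of > 100 ug/mL in this assay, at which 1 of the 3 values shown sits. Its neighbours in the set are measured. Compound 1, `c1ccc(-c2cc(-c3ccsc3)cc(-c3ccccn3)n2)nc1`, gives 0.29 ug/mL in this assay, and compound 3, `c1ccc(-c2cc(-c3ccoc3)cc(-c3ccccn3)n2)nc1`, gives 0.06 ug/mL. For the measured compounds named here, the step of an at least 340-fold higher number from compound 1 to compound 2 (2.53 log units; beyond the scatter) is the one that set compound 2 at its limit, whereas the step of a 4.8-fold lower number from compound 1 to compound 3 (0.68 log units; beyond the scatter) shows that exchanging the five-membered ring is tolerated and can help.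

The compound still to be measured is compound 4, `c1ccc(-c2cc(-c3cccs3)cc(-c3cccnc3)n2)nc1`. The change from compound 2 is thiophen-2-yl in place of thiophen-3-yl on an aromatic carbon. Going by the values given here, no measured pair isolates this particular swap. Among the compounds with values here, the only step touching the five-membered ring, from compound 1 to compound 3, was modest, and the large loss in compound 2 came from the pyridin-3-yl group, which compound 4 keeps. A small step is therefore expected, of the size a number no higher from compound 2 to compound 4 (the limit leaves the size open), with no firm direction, and compound 4 is most likely to sit again at the limit of this assay. Compound 4 is thus estimated at 100 ug/mL, within a range from 30 ug/mL to 300 ug/mL.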

Compound 4, concentration for 50% growth inhibition: 56.1 ug/mL
Beside the measured number, compound 4's estimate is 1.8-fold (0.25 log units) above it; low and high end bracket the measured number.
By their numbers in this assay, from the lowest: compound 3; then compound 1; then compound 4. At a limit, above all of these: compound 2.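

With the same atoms joined differently, thiophen-2-yl in place of thiophen-3-yl on the carbon opposite the ring nitrogen gives compound 4, the only compound shown with a pyridin-3-yl group that has an actual number in this assay, so the pyridin-3-yl group does not by itself hold a compound at the limit. The change reads as an at least 1.7-fold lower number from compound 2 to compound 4 (0.25 log units; that floor lies within the scatter), and since this is only a floor, the true size of the step could lie anywhere from within the scatter to well beyond it. Compound 2 itself remains a limit and not a number: the limit of > 100 ug/mL in this assay, at which 1 of the 4 values shown sits.

On these data alone, it remains open whether the thiophen-2-yl group would give a similar result with the pyridin-2-yl group of compound 1, or how furan-2-yl would compare with the furan-3-yl group of compound 3. Also open, as far as these compounds go, is how a phenyl or a dimethylamino group on the carbon opposite the ring nitrogen, or a pyridin-4-yl group in place of the pyridin-3-yl group, would read in this assay.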